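A few compounds are considered here, and "the series" means these few. Any claim that something is new, unique, unknown or untested is made for them only; others in the source may bear on it.

In a functional assay on Right cardiac atrium for agonist activity at histamine H2 receptor (Cavia porcellus), with a stated time of 30 min, in the presence of a further agent that is not named here (a lower number here means that less compound is needed, a higher number that more compound is needed for the effect), compound 1 `Cc1nc(N)sc1CCCN/C(N)=N/C(=O)NC(C)c1ccc(Br)cc1` gives 55 nM. Within the data shown here, on the numbers so far compound 1 stands highest of the two measured compounds; its nearest neighbour is compound 2 `Cc1nc(N)sc1CCCN/C(N)=N/C(=O)NC(C)c1ccccc1F`, which in this assay gives 12.3 nM, and that step was a 4.5-fold lower number from compound 1 to compound 2 (0.65 log units; beyond the scatter), a 2-fluorophenyl in place of a 4-bromophenyl. Compound 3 `Cc1nc(N)sc1CCCN/C(N)=N/C(=O)NC(C)c1ccc(OC(F)(F)F)cc1` has not yet been measured; it differs from compound 1 by trifluoromethoxy in place of bromo on an aromatic carbon. Among the measured compounds shown here, the one measured step replaces the whole aryl group and shifts the substituent to another position, so it bears only loosely on a change that keeps the ring substitution pattern and swaps one group for another. For the measured compounds named here, no direct precedent for this exchange exists among the measured compounds. Compound 3 is therefore expected to give 60 nM, with a range of 20 nM to 180 nM, which means an expected step of a 1.1-fold higher number from compound 1 to compound 3 (0.04 log units; within the scatter) that is not beyond the scatter.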

Compound 3, half-maximal effective concentration: 724 nM
Beside the measured number, compound 3's estimate is 12-fold (1.08 log units) below it; measured number outside the range, above it.
By their numbers in this assay, from the lowest: compound 2; then compound 1; then compound 3.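

At this aromatic carbon, para to a large group, the exchange of one substituent for another is far from neutral in this assay: trifluoromethoxy in place of bromo gives a 13-fold higher number from compound 1 to compound 3 (1.12 log units; beyond the scatter). This single exchange, with the ring substitution pattern unchanged, moves the number further than the replacement of the whole aryl group, which gave a 4.5-fold lower number from compound 1 to compound 2 (0.65 log units; beyond the scatter), so the choice of substituent at this carbon matters on its own. Nothing measured on these groups accounts for the size of the step.

Going by these compounds, whether a methoxy or a trifluoromethyl group at this carbon would give a number nearer to that of compound 1 or to that of compound 3 remains open. Also open, on these data alone, is whether the exchange of bromo for trifluoromethoxy would give a step of similar size with another core.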